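This account rests on a few compounds, and the source may have more. Where it says the series, first, only, none or still open, it means among the compounds named here.

Compound 2 `Nc1nc(OCc2ccccc2)c2ncn(/C=C3/CC3(CO)CO)c2n1` carries a benzyloxy group and belongs to the same series as compound 1 `CCOc1nc(N)nc2c1ncn2/C=C1/CC1(CO)CO` and compound 3 `CCCNc1nc(N)nc2c1ncn2/C=C1/CC1(CO)CO`. In an ADME assay on BCBL1 cells (Homo sapiens) for cytotoxicity, with a stated time of 7 days (a higher number here means that more compound is tolerated, a lower number that less compound is tolerated), compound 2 reaches only the limit of the assay, > 20000 nM. Compound 1 likewise gives only a limit, > 20000 nM. Compound 3 also gives a limit, > 20000 nM. Because (the limit of > 20000 nM in this assay, at which 3 of the 3 values shown sit), none of the steps among them can be read: a step that the two limits leave unreadable from compound 1 to compound 2, a step that the two limits leave unreadable from compound 1 to compound 3 and a step that the two limits leave unreadable from compound 2 to compound 3. Compound 4 `CSc1nc(N)nc2c1ncn2/C=C1/CC1(CO)CO` is not yet measured; it differs from compound 2 thus: methylsulfanyl in place of benzyloxy on an aromatic carbon. Among the compounds with values here, no measured step gives a readable size for this change; the only guide is that every value so far sits at the limit. Compound 4 is therefore expected to sit near that same limit in this assay, with an estimated step of a number no higher from compound 2 to compound 4 (the limit leaves the size open). The estimate for compound 4 is 20000 nM, from 10000 nM to 40000 nM.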

Compound 4, half-maximal cytotoxic concentration: > 20000 nM
Compound 4 gave a limit, no number; the forecaster's own chance of this, stated with the estimate: 85%; the middle value lies on the limit itself.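

Within the data shown here, compound 4 also gives only a limit in this assay, so no step linking it to compound 1, compound 2 or compound 3 can be read: the limit of > 20000 nM in this assay, at which 4 of the 4 values shown sit. The compounds shown leave open whether exchanging these groups on the aromatic carbon changes how much compound is tolerated.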